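The source may report more compounds than this note shows. Statements on the series, on what has been measured and on what is new or still open speak of the compounds shown alone.

Compound 1 `Nc1nc(OCc2ccccc2)c2ncn(/C=C3/CC3(CO)CO)c2n1` is the starting point. In an ADME assay on BCBL1 cells (Homo sapiens) for cytotoxicity, with a stated time of 7 days (a higher number here means that more compound is tolerated, a lower number that less compound is tolerated), compound 1 gives > 20000 nM, which is a limit of the assay rather than a number. Compound 2 `Nc1nc2c(ncn2/C=C2/CC2(CO)CO)c(=O)[nH]1` shares its core. In this assay compound 2 gives > 20000 nM, again a limit. Compound 1 therefore stands only at the limit of > 20000 nM in this assay, at which 2 of the 2 values shown sit, with nothing above or below it to compare. Compound 3 `Nc1nc(NC2CCCCC2)c2ncn(/C=C3/CC3(CO)CO)c2n1` carries the change (cyclohexylamino in place of benzyloxy on an aromatic carbon). Within the data shown here, with no measured step to guide the move, the step that the limit leaves unreadable from compound 1 to compound 3 is expected to stay within the scatter. For compound 3 the value in this assay is estimated at 30000 nM, likely between 12000 nM and 80000 nM.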

Compound 3, half-maximal cytotoxic concentration: > 20000 nM
Compound 3 ended at the assay's limit (the forecaster's own chance of this, stated with the estimate: 70%); the middle value lies beyond the limit too.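

In this assay compound 3 gives > 20000 nM, which is a limit of the assay. Among these compounds, no step from compound 1 to compound 3 can therefore be read: the limit of > 20000 nM in this assay, at which 3 of the 3 values shown sit. The concentration at which any of these compounds becomes toxic to the cells remains open.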